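This account rests on a few compounds, and the source may have more. Where it says the series, first, only, none or still open, it means among the compounds named here.

Measured in a functional assay on HeLa cells (Homo sapiens) for inhibition, read by CCK-8 assay, with a stated time of 72 h, tested at 8 uM; on this read-out lower numbers stand for less inhibition of growth and higher numbers for more inhibition of growth at the one concentration tested:

- compound 1 `Nc1ccccc1NC(=O)c1ccc(CSc2cccc(F)c2)cc1`: 78.4%
- compound 2 `Nc1ccccc1NC(=O)/C=C/c1ccc(CSc2ccc(C(F)(F)F)cn2)cc1`: 6.82%
- compound 3 `Nc1ccccc1NC(=O)/C=C/c1ccc(CSc2ccc(F)cc2)cc1`: 10.4%

Compound 1, at 78.4%, is the highest of the three, and compound 2 and compound 3 both lie below it by more than the scatter. Compound 4 `Nc1ccccc1NC(=O)c1ccc(CSc2ccc(F)cc2)cc1` keeps the core of compound 1 and changes one group: 4-fluorophenyl in place of 3-fluorophenyl on a sulfur. In words, 4-fluorophenyl stands in place of 3-fluorophenyl on a sulfur.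

Among the compounds with values here, no measured pair compares these two groups directly. Within the data shown here, the one measured exchange on a sulfur is a number 3.6 percentage points higher from compound 2 to compound 3 (within the scatter). That step also ends in 4-fluorophenyl, but it lies on a different core and at the low end of the numbers, so it is only loose guidance. No step beyond the scatter is therefore expected in this assay, and neither direction is favoured with any confidence. The expected change is a number 3.4 percentage points lower from compound 1 to compound 4 (within the scatter). For compound 4 the estimated value is 75%, with an expected range from 55% to 90%.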

Compound 4, percent growth inhibition at one concentration: 79.3%
Estimate against measurement, compound 4: 4.3 percentage points below; low and high end bracket the measured number.
By their numbers in this assay, from the lowest: compounds 2 and 3 (each within the scatter of the next); then compounds 1 and 4 (each within the scatter of the next).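

In this assay, within the data shown here, 4-fluorophenyl in place of 3-fluorophenyl on a sulfur gives a number 0.9 percentage points higher from compound 1 to compound 4 (within the scatter), the first direct comparison of these two groups. On the core of compound 1, the two fluorophenyl groups therefore cannot be told apart in this assay at the one concentration tested. The same 4-fluorophenyl on a sulfur appears in compound 4, at 79.3%, and in compound 3, at 10.4%, so the group alone does not set the number across these two cores. Nothing measured here gives a reason for this result.

The compounds shown leave open whether a cyclohexyl group or a carboxylic acid-bearing phenyl on the sulfur would hold the number on the core of compound 1. A single concentration also leaves open whether compound 1 and compound 4 would stay together across a full concentration range.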